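The compounds below may be only part of what the source reports. "The series", "measured", "known", "first", "only" and "open" are said of these compounds alone.

Measured compounds:
- compound 1, `O=C(CCCCC[C@H](NC(=O)c1ccc(Br)cc1)C(=O)Nc1ccc(-c2ccccc2)cc1)NO`: in a functional assay on C180-13S cells (Homo sapiens) for antiproliferative activity (on this read-out higher numbers stand for weaker inhibition and lower numbers for stronger inhibition), compound 1 gives 158 nM.
- compound 2, `CN(C)c1ccc(C(=O)N[C@@H](CCCCCC(=O)NO)C(=O)Nc2cccc3cccnc23)cc1`: in this assay compound 2 gives 65 nM.

Compound 2 stands at the lower of the two numbers; compound 1 sits higher by a gap beyond the usual scatter. Among the compounds with values here, no two measured compounds differ in a single place, so no isolated step is known.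

Compound 3, `O=C(/C=C/c1ccccc1)N[C@@H](CCCCCC(=O)NO)C(=O)Nc1cccc2cccnc12`, shares the core of compound 2 and is altered only at the amide cap: 2-phenylethenyl in place of 4-(dimethylamino)phenyl on a carbonyl carbon. One aromatic group is exchanged for another, the hydrogen-bond acceptor counted in the leaving group is lost, and a double bond outside aromatic rings comes in. Nothing has been measured on this kind of cap exchange, so the expectation in this assay is a step of modest size toward a somewhat higher number, one that need not clear the scatter. The expected change reads a 1.5-fold higher number from compound 2 to compound 3 (0.16 log units; within the scatter). Compound 3 is estimated at 95 nM, with a range from 35 nM to 260 nM.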

Compound 3, half-maximal inhibitory concentration: 28 nM
The estimate for compound 3 lay 3.4-fold (0.53 log units) above the measured number; the whole stated range lies above it.
By their numbers in this assay, from the lowest: compound 3; then compound 2; then compound 1.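

In this assay, the amide cap now has a readable single change: 2-phenylethenyl in place of 4-(dimethylamino)phenyl on a carbonyl carbon gives a 2.3-fold lower number from compound 2 to compound 3 (0.37 log units; beyond the scatter) and so clears the scatter in the direction of stronger inhibition. This position therefore responds to the exchange of one aromatic cap for another, and a lower number here requires neither the dimethylamino nitrogen nor its hydrogen-bond acceptor, since the entering group has no hydrogen-bond acceptor and instead carries a double bond outside aromatic rings. No data at hand give a reason for this step.

The exchange removes the dimethylamino group and brings in the double bond in a single move, so the share of each remains unresolved; a plain phenyl or a saturated 2-phenylethyl group on the same carbonyl carbon would separate the two. As far as these compounds go, it also remains open whether 2-phenylethenyl gives a step of similar direction and size on other cores, such as the core of compound 1.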